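Sulfonyl for dienoyl on the long-chain threonine amides

This account rests on a few compounds, and the source may have more. Where it says the series, first, only, none or still open, it means among the compounds named here.

Compound 1 `C/C=C/C=C/C(=O)N[C@H](C(=O)NCCCCCCCCCCCCCC)[C@@H](C)O` and compound 3 `C/C=C/C=C/C(=O)N[C@H](C(=O)NCCCCCCCCCCCCCCCCCC)[C@@H](C)O` share a core and differ by butyl in place of hydrogen on a saturated chain carbon, ten or more bonds along the chain from an amide-type nitrogen. In a functional assay on SW-620 cells (Homo sapiens) for cytotoxicity, read by MTT assay, with a stated time of 48 h (on this read-out higher numbers stand for weaker inhibition and lower numbers for stronger inhibition), compound 1 gives 200000 nM, and compound 3 gives 200000 nM; no change at the digits printed from compound 1 to compound 3 (within the scatter). Compound 2 `CCCCCCCCCCCCCCNC(=O)[C@@H](NS(=O)(=O)c1ccc(C)cc1)[C@@H](C)O` carries one change on the core of compound 1, ((4-methylphenyl)sulfonyl in place of (penta-1,3-dien-1-yl)carbonyl on an amine nitrogen). In this assay compound 2 gives 15200 nM, and a 13-fold lower number from compound 1 to compound 2 (1.12 log units; beyond the scatter). Compound 4 `CCCCCCCCCCCCCCCCCCNC(=O)[C@@H](NS(=O)(=O)c1ccc(C)cc1)[C@@H](C)O` is not yet measured; it carries the same change on the core of compound 3, ((4-methylphenyl)sulfonyl in place of (penta-1,3-dien-1-yl)carbonyl on an amine nitrogen), at the same place. The change is seen measured only once, so the expectation for compound 4 rests on that single step. Within the data shown here, for compound 4 the expected step is a 13-fold lower number from compound 3 to compound 4 (1.12 log units; beyond the scatter), because a 13-fold lower number from compound 1 to compound 2 (1.12 log units; beyond the scatter) is the only guide. Compound 4 is therefore estimated at 15000 nM in this assay, with the range 5000 nM to 50000 nM expected.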

Compound 4, half-maximal inhibitory concentration: 32500 nM
The estimate for compound 4 lay 2.2-fold (0.34 log units) below the measured number; measured number inside the range.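

In this assay the change to (4-methylphenyl)sulfonyl carries over to the core of compound 3, with a 6.2-fold lower number from compound 3 to compound 4 (0.79 log units; beyond the scatter), and the size of the step agrees with the earlier one within the scatter: the same change on two cores in this assay, a 13-fold lower number (1.12 log units; beyond the scatter) from compound 1 to compound 2 and a 6.2-fold lower number (0.79 log units; beyond the scatter) from compound 3 to compound 4, 2.1-fold (0.33 log units) apart, within the scatter of two such steps. The added butyl gives a 2.1-fold higher number from compound 2 to compound 4 (0.33 log units; beyond the scatter), while the pair carrying (penta-1,3-dien-1-yl)carbonyl stays level, and this gap also lies within the scatter: the same change on two cores in this assay, no change at the digits printed (within the scatter) from compound 1 to compound 3 and a 2.1-fold higher number (0.33 log units; beyond the scatter) from compound 2 to compound 4, 2.1-fold (0.33 log units) apart, within the scatter of two such steps. The two cores show that the step keeps its direction here, but not that it would hold on any other core.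

From the compounds shown here alone, whether phenylsulfonyl or methylsulfonyl on the amine nitrogen would give a similar step remains open. So does the result with a shorter chain on the amide-type nitrogen.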